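Swapping the Aryl Ether of Compound 3 for Chlorophenyl

The source may hold more compounds than are shown below. What is called first, only, known or untested is meant among the compounds shown, and "the series" means these compounds.

Compound 3 `CNC(=O)c1cccc(Cn2nc(C)c(NC(=O)c3ccc(COc4ccccc4OC)cc3)c2C)c1` carries a (2-methoxyphenoxy)methyl group and, in a functional assay on MIA PaCa-2 cells (Homo sapiens) for antiproliferative activity, read by MTT assay, with a stated time of 72 h (on this read-out higher numbers stand for an effect only at larger amounts of compound and lower numbers for an effect already at smaller amounts), compound 3 gives 8500 nM. Among the three measured compounds this is the lowest number, but its neighbours lie close: compound 1 `CCNC(=O)c1cccc(Cn2nc(C)c(NC(=O)c3ccc(COc4ccccc4)cc3)c2C)c1` gives 11000 nM and compound 2 `CNC(=O)c1cccc(Cn2nc(C)c(NC(=O)c3ccc(COC4CCCCC4)cc3)c2C)c1` gives 14000 nM, and both gaps fall within the scatter, so no order among the three can be claimed.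

Compound 4 `CNC(=O)c1cccc(Cn2nc(C)c(NC(=O)c3ccc(COc4ccc(Cl)cc4)cc3)c2C)c1` is not yet measured. Its difference from compound 3 is 4-chlorophenyl in place of 2-methoxyphenyl on an oxygen on a saturated carbon. Among the measured compounds shown here, one measured step bears on this kind of exchange: a 1.6-fold lower number from compound 2 to compound 3 (0.22 log units; within the scatter). There the group on the oxygen on a saturated carbon was traded from cyclohexyl to 2-methoxyphenyl without moving the number beyond the scatter. For the measured compounds named here, compound 1 differs from compound 3 in two places at once, so its value shows only that the numbers of the whole set stay close together.

Against this flat background, compound 4 is expected to stay within the scatter of compound 3, a step of a 1.2-fold higher number from compound 3 to compound 4 (0.07 log units; within the scatter). The estimate for compound 4 in this assay is 10000 nM, with a range from 4000 nM to 25000 nM.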

Compound 4, half-maximal effective concentration: 4200 nM
Estimate against measurement, compound 4: 2.4-fold (0.38 log units) above, and the stated range covers the measured number.
By their numbers in this assay, from the lowest: compound 4; then compounds 3, 1 and 2 (each within the scatter of the next).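

In this assay, the group on the oxygen on a saturated carbon now produces steps beyond the scatter, which the earlier exchange from cyclohexyl to 2-methoxyphenyl did not: there is a 2.0-fold lower number from compound 3 to compound 4 (0.31 log units; beyond the scatter) and also a 3.3-fold lower number from compound 2 to compound 4 (0.52 log units; beyond the scatter), both of them modest. This place therefore responds to the group it carries, though only to a limited extent, and among the three compounds that differ here alone, 4-chlorophenyl gives a lower number than either 2-methoxyphenyl or cyclohexyl. Nothing available explains why the number falls with this exchange.

The exchange swaps the methoxy group for chlorine and also moves the group from the 2-position to the 4-position of the ring, so the compounds shown cannot separate these two changes, which 2-chlorophenyl and 4-methoxyphenyl would pull apart. From the compounds shown here alone, it also remains open whether the number falls further with 3,4-dichlorophenyl or 4-bromophenyl, and whether it holds with a ring carrying an amine or a carboxylic acid.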